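The source may report more compounds than this note shows. Statements on the series, on what has been measured and on what is new or still open speak of the compounds shown alone.

Measured so far in a functional assay, with a stated time of 150 min, tested at 35 ug/mL; a higher number here means a stronger effect of the compound at the concentration tested, a lower number a weaker effect:
compound 1 `COC(=O)c1c(Nc2ccc(C)cc2)sc(C(=O)c2ccc(C)cc2)c1C` — "not active" (no number reported)
compound 2 `COc1ccc(C(=O)c2sc(Nc3ccc(C)cc3)c(C(=O)O)c2C)cc1` — "not active" (no number reported)
compound 3 `Cc1ccc(C(=O)c2sc(Nc3ccccc3)c(C(=O)O)c2C)cc1` — 5.55%

Compound 3 holds the only number in the series; for compound 1 and compound 2 this assay reported no number, only the outcome given above. The next entry, compound 4 `Cc1ccc(Nc2sc(C(=O)c3ccc(C)cc3)c(C)c2C(=O)O)cc1`, is still to be measured in this assay. Its difference from compound 3 is methyl in place of hydrogen on an aromatic carbon on the anilino ring.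

For the measured compounds named here, no step between two measured compounds is available, so no size can be read off. The change is a single added carbon, and with compound 3 at 5.55% any shift is expected to stay within the usual scatter, in no clear direction. For compound 4 the expected value in this assay is 5%, between 0% and 14%, which corresponds to an expected step of a number 0.6 percentage points lower from compound 3 to compound 4 (within the scatter).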

Compound 4, a percentage reported as activity, at one concentration (the size of the read-out at that concentration, not a potency): "not active" (no number reported)
No number was reported for compound 4, and the estimate cannot be compared.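

For the compounds shown here, compound 4 gives "not active" (no number reported) in this assay, so no step from compound 3 to compound 4 can be read. The compounds shown leave open how methyl on the anilino ring shifts this read-out. No measured evidence bears on this result.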